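Chloro for Methyl, Carried from One Core to Another

The compounds below may be only part of what the source reports. "The series", "measured", "known", "first", "only" and "open" are said of these compounds alone.

Compound 1 `Cc1ccc(S(=O)(=O)Nc2cccc([N+](=O)[O-])c2)cc1`: 8.27
Compound 2 `O=[N+]([O-])c1cccc(NS(=O)(=O)c2ccc(Cl)cc2)c1`: 7.51
Compound 3 `Cc1ccc(S(=O)(=O)Nc2ccc(F)cc2)cc1`: 9.2

All three numbers come from an ADME assay. Compound 3 stands highest of the three, beyond the scatter above each of the others, and compound 2 stands lowest. Compound 1 and compound 2 differ in one place, (chloro in place of methyl on an aromatic carbon), and that change made a step of a number 0.76 log units lower from compound 1 to compound 2 (beyond the scatter). How the core of compound 3 differs from the core of compound 1 is not broken down here.

Compound 4 `O=S(=O)(Nc1ccc(F)cc1)c1ccc(Cl)cc1` has not yet been measured in this assay. Among the measured compounds shown here, it differs from compound 3 by chloro in place of methyl on an aromatic carbon, the same change, at the same kind of place, as the one that separates compound 1 from compound 2. For the measured compounds named here, a step of about the same size is therefore expected from compound 3 to compound 4, namely a number 0.75 log units lower from compound 3 to compound 4 (beyond the scatter), because the only measured example of this change is a number 0.76 log units lower from compound 1 to compound 2 (beyond the scatter). Compound 4 is thus estimated to give 8.45 in this assay, with a range expected from 8.05 to 8.85.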

Compound 4, acid dissociation constant: 8.41
Compound 4: middle estimate off by 0.04 log units, on the high side; low and high end bracket the measured number.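

In this assay, chloro in place of methyl on an aromatic carbon made a step of a number 0.79 log units lower from compound 3 to compound 4 (beyond the scatter), so the change kept its direction on the second core. Its size also held from the core of compound 1 to the core of compound 3: the same change on two cores in this assay, a number 0.76 log units lower (beyond the scatter) from compound 1 to compound 2 and a number 0.79 log units lower (beyond the scatter) from compound 3 to compound 4, 0.03 log units apart, within the scatter of two such steps This shows that in these two pairs the step carried over intact, but two pairs at one kind of place, para to a large group, do not show that it would hold on every core in the series, and they do not explain why the step has this size.

The compounds shown leave open how another group at that place, such as a methoxy group, a trifluoromethyl group or an amine, would move the number. They also leave open whether chloro would give a step of similar size elsewhere on the ring, or on a core other than these two.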